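A few compounds are considered here, and "the series" means these few. Any claim that something is new, unique, unknown or untested is made for them only; others in the source may bear on it.

Three compounds have been measured in an assay on HeLa cells with Bile acid receptor (Homo sapiens) as the target, read by a luciferase reporter, with a stated time of 24 h; a lower number here means that less compound is needed, a higher number that more compound is needed for the effect:

Compound 1, `CC(C)(C)c1ccc(C(=O)NCc2ccc(C(=O)O)cc2F)cc1`: 7.8 nM
Compound 2, `O=C(O)c1ccc(CNC(=O)c2ccc3ccccc3c2)cc1`: 1360 nM
Compound 3, `CC(C)(C)c1ccc(C(=O)NCc2ccc(S(C)(=O)=O)cc2)cc1`: 3800 nM

Among these three, compound 1 has the lowest number, so it needs the least material for the effect. The gap from compound 1 up to compound 2 lies far beyond the usual scatter of repeated measurements, and the gap up to compound 3 is wider still. On this small set, compound 1 stands clearly apart from the other two.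

Compound 4, `CC(C)(C)c1ccc(C(=O)NCc2ccc(C(=O)O)cc2Cl)cc1`, has not yet been measured in this assay. It differs from compound 1 in one place: chloro in place of fluoro on an aromatic carbon. The core, the amide link and the carboxy group are all kept; only one halogen is exchanged for another.

Within the data shown here, no pair of measured compounds shows what such a halogen exchange does here, so there is no measured step to lean on. An exchange of one heavy atom for one heavy atom, with no change in hydrogen-bond donors, acceptors or charge, is expected to shift the number only a little, in no firm direction. Compound 4 is therefore expected to land close to compound 1, with the estimated step of a 1.3-fold higher number from compound 1 to compound 4 (0.11 log units; within the scatter) inside the usual scatter. The estimate for compound 4 is 10 nM, with a range from 3 nM to 35 nM.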

Compound 4, half-maximal effective concentration: 7500 nM
Estimate against measurement, compound 4: 750-fold (2.88 log units) below; the measured number lies above the stated range.
By their numbers in this assay, from the lowest: compound 1; then compound 2; then compounds 3 and 4 (each within the scatter of the next).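

In this assay, exchanging one halogen for another on this aromatic carbon, ortho to a large group and meta to a carboxy group, gives a 960-fold higher number from compound 1 to compound 4 (2.98 log units; beyond the scatter). The earlier compounds shown here offered no step in a single place, and this first one shows that the position is highly sensitive to the change: the heavy-atom count, hydrogen-bond donors, hydrogen-bond acceptors and net charge all stay the same, yet the number moves far beyond the scatter. No measurement at hand accounts for the size of this step.

With only fluoro and chloro shown at this position, a single step cannot tell whether fluoro is unusually good here or chloro unusually poor. A compound carrying plain hydrogen, a methyl group or a bromo on this same carbon would place both halogens on a wider scale, and would show whether the number climbs steadily with the size of the group or changes only for chloro.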